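Swapping Chloro for Fluoro on the Fused Ring

The source may report more compounds than this note shows. Statements on the series, on what has been measured and on what is new or still open speak of the compounds shown alone.

Three rhodanine acetic acids sharing a common core have been tested in a functional assay on HeLa cells (Homo sapiens) for cytotoxicity, read by MTT assay, with a stated time of 48 h; a higher number here means a weaker inhibitor, a lower number a stronger inhibitor. Compound 1 `O=C(O)CN1C(=O)/C(=C/c2nc3ccccc3n2Cc2ccc(F)cc2)SC1=S` gives 13900 nM in this assay. Compound 2 `O=C(O)CN1C(=O)/C(=C/c2nc3ccccc3n2Cc2ccc(Cl)cc2)SC1=S` gives 8720 nM, and compound 3 `O=C(O)CN1C(=O)/C(=C/c2nc3ccc(Cl)cc3n2Cc2ccccc2F)SC1=S` gives 7620 nM. The three numbers sit close together, so none of these compounds can be called stronger or weaker than another.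

Compound 2 and compound 1 differ in one place: fluoro in place of chloro on an aromatic carbon. That change produced a 1.6-fold higher number from compound 2 to compound 1 (0.20 log units; within the scatter). The difference between the core of compound 2 and the core of compound 3 is not broken down here.

Compound 4 `O=C(O)CN1C(=O)/C(=C/c2nc3ccc(F)cc3n2Cc2ccccc2F)SC1=S` has not yet been measured in this assay. It differs from compound 3 in one place: fluoro in place of chloro on an aromatic carbon. Among the measured compounds shown here, this is the same kind of change as the one from compound 2 to compound 1, but not the same one, since in the earlier pair the change sat on a six-membered aromatic ring para to a large group, whereas here it sits on a ring that is part of a fused system, meta to a fused ring and para to a fused ring.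

Because the earlier step was a 1.6-fold higher number from compound 2 to compound 1 (0.20 log units; within the scatter), the step from compound 3 to compound 4 in this assay is expected to be small as well, roughly a 1.3-fold higher number from compound 3 to compound 4 (0.12 log units; within the scatter). Compound 4 is accordingly estimated at 10000 nM in this assay, with a likely range from 5000 nM to 22000 nM.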

Compound 4, half-maximal inhibitory concentration: > 50000 nM
Compound 4 was reported as a limit; the forecaster's own chance of this, stated with the estimate: 5%; middle value at least 5.0-fold (0.69 log units) away from the limit.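

Compound 4 gives > 50000 nM in this assay, which is a limit of the assay and not a number. Fluoro in place of chloro on an aromatic carbon therefore gave an at least 6.5-fold higher number from compound 3 to compound 4 (0.81 log units; beyond the scatter), and the size of the step did not carry over from one core to the other: the same change on two cores in this assay, a 1.6-fold higher number (0.20 log units; within the scatter) from compound 2 to compound 1 and an at least 6.5-fold higher number (0.81 log units; beyond the scatter) from compound 3 to compound 4, at least 4.1-fold (0.61 log units) apart, beyond the scatter of two such steps. This shows that, in this series, the step on one core was a poor guide to the step on the other, but it rests on two pairs only, which differ both in their cores and in the ring carrying the change, so it does not show which of these differences matters, and the full size of the new step stays unread: the limit of > 50000 nM in this assay, at which 1 of the 4 values shown sits.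

The compounds shown leave open how other groups would fare on the ring that is part of the fused system, for instance bromo, methyl or methoxy in place of the chloro of compound 3. They also leave open whether the same swap would give a step of similar size on a core in which an amide or an ester stands in place of the carboxylic acid.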